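A few compounds are considered here, and "the series" means these few. Any claim that something is new, unique, unknown or untested is made for them only; others in the source may bear on it.

For the measured compounds named here, in a functional assay (Pituitary gland cell) with Rattus norvegicus as the target (a lower number here means that less compound is needed, a higher number that more compound is needed for the effect), compound 2 `CCCNC(=O)NCc1ccccc1-c1ccc(CN2C(=O)[C@H](NC(=O)C(C)(C)N)CCc3ccccc32)cc1` gives 144 nM, the second highest of the three numbers so far. That value lies within the scatter of compound 3 `CC(=O)NCc1ccccc1-c1ccc(CN2C(=O)[C@H](NC(=O)CC(C)(C)N)CCc3ccccc32)cc1` at 200 nM, while compound 1 `CNC(=O)Nc1ccccc1-c1ccc(CN2C(=O)[C@H](NC(=O)CC(C)(C)N)CCc3ccccc32)cc1` has the lowest number at 50 nM.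

Compound 4 `CC(C)(N)C(=O)N[C@@H]1CCc2ccccc2N(Cc2ccc(-c3ccccc3-c3nn[nH]n3)cc2)C1=O` keeps the core and the amine-bearing side chain of compound 2 and changes one group: 2H-tetrazol-5-yl in place of ((propylcarbamoyl)amino)methyl on an aromatic carbon. In short, a 2H-tetrazol-5-yl replaces a much longer open chain.

Going by the values given here, only one measured step offers a guide, an exchange of one group for another on an aromatic carbon: a 4.0-fold higher number from compound 1 to compound 3 (0.60 log units; beyond the scatter). It shows that a swap of this kind can move the number by a modest amount. It is indirect evidence, though, since compound 1 and compound 3 carry a different amine-bearing side chain from compound 2. None of the three measured compounds has a tetrazole, so the direction of the change cannot be read from the data.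

With no direction to go on, no shift beyond the scatter is expected, and the expected change is a 1.0-fold higher number from compound 2 to compound 4 (0.02 log units; within the scatter). For compound 4 the estimated value is 150 nM, with an expected range from 40 nM to 550 nM.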

Compound 4, concentration for half-maximal effect: 30 nM
Estimate against measurement, compound 4: 5.0-fold (0.70 log units) above; the whole stated range lies above it.
By their numbers in this assay, from the lowest: compounds 4 and 1 (each within the scatter of the next); then compounds 2 and 3 (each within the scatter of the next).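

In this assay, putting a 2H-tetrazol-5-yl in place of the ((propylcarbamoyl)amino)methyl chain gives a 4.8-fold lower number from compound 2 to compound 4 (0.68 log units; beyond the scatter), so on this aromatic carbon, ortho to a large group, the open chain is not needed for the effect, and a five-membered aromatic ring with fewer heavy atoms gives a lower number. For the compounds shown here, the earlier step, a 4.0-fold higher number from compound 1 to compound 3 (0.60 log units; beyond the scatter), exchanged one open chain for another on a different amine-bearing side chain, so it showed only that this place responds to change; the new step is the first to show a direction for a ring there. Nothing measured here explains why this exchange lowers the number.

As far as these compounds go, whether the ring is what matters, or simply the loss of the chain, remains open: a carboxylic acid, a plain amine or a five-membered aromatic ring with fewer nitrogen atoms on the same carbon would help to separate the two. From the compounds shown here alone, it is also open whether the 2H-tetrazol-5-yl would lower the number in the same way when paired with the different amine-bearing side chain of compound 1 and compound 3.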